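A few compounds are considered here, and "the series" means these few. Any claim that something is new, unique, unknown or untested is made for them only; others in the source may bear on it.

Three compounds built on a shared core differ only in the group carried on one aromatic carbon. Compound 1 `Cc1cc(-c2cccc(F)c2)cc(C)c1Nc1ccnc(Nc2ccc(C#N)cc2)n1` gives 4120 nM in an ADME assay on MT4 cells (Homo sapiens) for cytotoxicity, read by MTT assay, with a stated time of 4 days; a higher number here means that more compound is tolerated, a lower number that less compound is tolerated. Compound 2 `Cc1cc(-c2c(C)cccc2C)cc(C)c1Nc1ccnc(Nc2ccc(C#N)cc2)n1` gives 2590 nM in this assay, and compound 3 `Cc1cc(-c2cc(F)cc(F)c2)cc(C)c1Nc1ccnc(Nc2ccc(C#N)cc2)n1` gives 3910 nM in this assay. Compound 3 sits among these three values, separated from compound 1 by a 1.1-fold lower number from compound 1 to compound 3 (0.02 log units; within the scatter) and from compound 2 by a 1.5-fold higher number from compound 2 to compound 3 (0.18 log units; within the scatter); the remaining pair shows a 1.6-fold lower number from compound 1 to compound 2 (0.20 log units; within the scatter).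

Compound 4 `Cc1cc(-c2cccc(C#N)c2)cc(C)c1Nc1ccnc(Nc2ccc(C#N)cc2)n1` has not yet been tested. Its structure differs from that of compound 3 in one place: 3-cyanophenyl in place of 3,5-difluorophenyl on an aromatic carbon. Among the measured compounds shown here, every measured step so far alters this same position, and none of them carried the number beyond the scatter, so exchanging one substituted phenyl for another has so far left this assay essentially where it was. On that basis compound 4 is expected to remain close to compound 3, with a step of a 1.0-fold lower number from compound 3 to compound 4 (0.00 log units; within the scatter). The estimate for compound 4 in this assay is 3900 nM, within a range of 1800 nM to 8500 nM. For the measured compounds named here, the nitrile brings the first hydrogen-bond acceptor to this position among the four compounds, and no measured step speaks to that feature.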

Compound 4, half-maximal cytotoxic concentration: 920 nM
Compound 4: middle estimate off by 4.2-fold (0.63 log units), on the high side; measured number below the stated range.
By their numbers in this assay, from the lowest: compound 4; then compounds 2, 3 and 1 (each within the scatter of the next).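

This position is not indifferent in this assay: the exchanges among the earlier substituted phenyl groups all stayed within the scatter, but 3-cyanophenyl in place of 3,5-difluorophenyl gives a 4.3-fold lower number from compound 3 to compound 4 (0.63 log units; beyond the scatter) and the same group in place of 2,6-dimethylphenyl gives a 2.8-fold lower number from compound 2 to compound 4 (0.45 log units; beyond the scatter), which leaves compound 4 with the lowest number of the four. Even the exchange of a single substituent, cyano in place of fluoro, gives a 4.5-fold lower number from compound 1 to compound 4 (0.65 log units; beyond the scatter), and so the change of group at this place is enough to lower the number beyond the scatter, and the 3-cyanophenyl group is the only one of the four that counts a hydrogen-bond acceptor, although a single compound cannot tie the step to that feature. Nothing available accounts for the step, and its cause remains unknown.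

Going by these compounds, whether a methoxy group, an amide or a carboxylic acid on this ring would lower the number as the nitrile does remains open. On these data alone, it is also open whether the nitrile would give the same step with the two fluorines of compound 3 partly retained, or whether an amine or a longer chain at this place would do likewise.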